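This account rests on a few compounds, and the source may have more. Where it says the series, first, only, none or still open, it means among the compounds named here.

Compound 1 `Cc1cccc(S(=O)(=O)Nc2ccc(-c3nc4ccccc4o3)cc2)c1` gives in an assay on isolated protein for inhibition of malate dehydrogenase, mitochondrial (Sus scrofa), with stated times of 45 min and 30 min (on this read-out lower numbers stand for stronger inhibition and higher numbers for weaker inhibition), a value of > 63000 nM, which is a limit of the assay and not a number.
Compound 2 `C=Cc1ccc(S(=O)(=O)Nc2ccc3oc(-c4ccccc4)nc3c2)cc1` gives in this assay a value of > 63000 nM, again a limit of the assay.
Compound 3 `CS(=O)(=O)Nc1ccc(-c2nc3ccccc3o2)cc1` gives in this assay a value of > 63000 nM, also a limit of the assay.

On the numbers shown, compound 2 stands only at a limit, as do the other two compounds, so no order among them can be read. Compound 4 `CCc1ccc(S(=O)(=O)Nc2ccc3oc(-c4ccccc4)nc3c2)cc1` differs from compound 2 in one place: ethyl in place of vinyl on an aromatic carbon. Within the data shown here, the only step between measured compounds that differ in one place, a step that the two limits leave unreadable from compound 1 to compound 3, cannot be read because both of its values are limits, and it concerns a different position anyway, so no measured step bears directly on the change from compound 2 to compound 4. All three values sit at the same point, (the limit of > 63000 nM in this assay, at which 3 of the 3 values shown sit), and a small change of vinyl to ethyl gives no ground to expect anything else. Compound 4 is therefore expected to remain at the limit as well, a step that the limit leaves unreadable from compound 2 to compound 4 being the estimate. The estimate for compound 4 in this assay is 100000 nM, with a range from 30000 nM to 400000 nM.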

Compound 4, half-maximal inhibitory concentration: > 63000 nM
Compound 4 was reported as a limit (the forecaster's own chance of this, stated with the estimate: 85%); the middle value does not contradict the limit.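

Among these compounds, compound 2 and compound 4 both stand at a limit in this assay, so the change from vinyl to ethyl gives no step that can be read: the limit of > 63000 nM in this assay, at which 4 of the 4 values shown sit. The compounds shown leave open whether any of them inhibits this enzyme measurably, and what change to their structures would give a readable value.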